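Bromine Substitution on Salicyl Hydrazones and Antiproliferative Potency

The source may hold more compounds than are shown below. What is called first, only, known or untested is meant among the compounds shown, and "the series" means these compounds.

Three compounds sharing a morpholine sulfonyl benzohydrazide framework were tested in a functional assay on PC-3 cells (Homo sapiens) for antiproliferative activity, read by MTT assay, with a stated time of 72 h; on this read-out higher numbers stand for weaker inhibition and lower numbers for stronger inhibition. Compound 1 `C/C(=N\NC(=O)c1cccc(S(=O)(=O)N2CCOCC2)c1)c1ccccc1O` gives 2810 nM. Compound 2 `C/C(=N\NC(=O)c1cccc(S(=O)(=O)N2CCOCC2)c1)c1cc(Br)ccc1O` differs from compound 1 in one place: bromo in place of hydrogen on an aromatic carbon. In this assay, within the data shown here, compound 2 gives 6890 nM, and the step of a 2.5-fold higher number from compound 1 to compound 2 (0.39 log units; beyond the scatter) is the only measured instance of this change. Compound 3 `O=C(N/N=C/c1cc(Br)ccc1O)c1cccc(S(=O)(=O)N2CCOCC2)c1` gives 7230 nM. The difference between the core of compound 3 and the core of compound 1 is not broken down here. The values of compound 3 and compound 2 lie within the scatter of each other.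

Compound 4 `O=C(N/N=C/c1cc(Br)cc(Br)c1O)c1cccc(S(=O)(=O)N2CCOCC2)c1` has not yet been measured. It differs from compound 3 by bromo in place of hydrogen on an aromatic carbon. This is the same kind of change as from compound 1 to compound 2, but not the same: in compound 2 the bromo sits meta to a large group and para to a hydroxy group, whereas in compound 4 it sits ortho to a hydroxy group, meta to a bromo group and meta to a large group. Among the measured compounds shown here, the expectation for compound 4 therefore rests on the one earlier step, and compound 4 is expected to show a step of a 1.7-fold higher number from compound 3 to compound 4 (0.22 log units; within the scatter) in this assay, of similar or somewhat smaller size, because the measured step of a 2.5-fold higher number from compound 1 to compound 2 (0.39 log units; beyond the scatter) was modest. Compound 4 is accordingly estimated at 12000 nM, within a range from 5000 nM to 30000 nM.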

Compound 4, half-maximal inhibitory concentration: 9700 nM
For compound 4 the middle estimate is 1.2-fold (0.09 log units) above the measured one; the measured number falls inside the stated range.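

In this assay, adding a second bromo to the 5-bromo-2-hydroxyphenyl ring gives a 1.3-fold higher number from compound 3 to compound 4 (0.13 log units; within the scatter), so compound 3 and compound 4 cannot be told apart on this read-out. The same change on the core of compound 1 gave a 2.5-fold higher number from compound 1 to compound 2 (0.39 log units; beyond the scatter), and the two instances cannot be distinguished from each other: the same change on two cores in this assay, a 2.5-fold higher number (0.39 log units; beyond the scatter) from compound 1 to compound 2 and a 1.3-fold higher number (0.13 log units; within the scatter) from compound 3 to compound 4, 1.8-fold (0.26 log units) apart, within the scatter of two such steps. This shows that the two results are compatible with a single modest step, but it does not establish that the change carries over from one core to another with a fixed size, since only two instances exist, only the first lies beyond the scatter, and in compound 4 the bromo enters ortho to a hydroxy group on a ring that already holds a bromo group.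

All four compounds keep the hydroxy group and the morpholine sulfonyl part, which leaves open how the step would read with a methoxy group in place of that hydroxy group or with a piperidine in place of the morpholine. Also open, going by these compounds, is whether a chloro or a methyl group at the carbon that takes the bromo would give a step of similar size on either core.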